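A nitrile in place of two fluorines on the benzyl group

The source may report more compounds than this note shows. Statements on the series, on what has been measured and on what is new or still open speak of the compounds shown alone.

Three measured compounds share one core and differ only in the group carried by an amine nitrogen in a ring. Compound 3 `CCN(CC)c1ccc2cc(C(=O)c3ccc(N4CCN(C(=O)CN5CCN(Cc6ccc(F)c(F)c6)CC5)CC4)cc3)oc2c1` carries a 3,4-difluorobenzyl there, and in a functional assay on MCF7 cells (Homo sapiens) for cytotoxicity, read by MTT assay, with a stated time of 48 h (on this read-out lower numbers stand for stronger inhibition and higher numbers for weaker inhibition), compound 3 gives 9220 nM. Compound 2 `CCN(CC)c1ccc2cc(C(=O)c3ccc(N4CCN(C(=O)CN5CCN(Cc6ccc(/C=C/C(=O)OC)cc6)CC5)CC4)cc3)oc2c1` carries a 4-(2-(methoxycarbonyl)ethenyl)benzyl instead, and in this assay compound 2 gives 8730 nM. Compound 1 `CCN(CC)c1ccc2cc(C(=O)c3ccc(N4CCN(C(=O)CN5CCN(S(=O)(=O)c6ccc(C#N)cc6)CC5)CC4)cc3)oc2c1` carries a (4-cyanophenyl)sulfonyl on that nitrogen. For compound 1 this assay reports only a limit, > 40000 nM. Compound 3 sits alongside compound 2, since a 1.1-fold higher number from compound 2 to compound 3 (0.02 log units; within the scatter), so the two cannot be told apart. Going by the values given here, the one step beyond the scatter is an at least 4.3-fold lower number from compound 1 to compound 3 (0.63 log units; beyond the scatter).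

Compound 4 `CCN(CC)c1ccc2cc(C(=O)c3ccc(N4CCN(C(=O)CN5CCN(Cc6ccc(C#N)cc6)CC5)CC4)cc3)oc2c1` has not yet been measured. 4-cyanophenyl in place of 3,4-difluorophenyl on a saturated chain carbon bound to an amine nitrogen in a ring Two measured steps bear on this. Exchanging one aryl substituent for another on the saturated chain carbon gave a 1.1-fold higher number from compound 2 to compound 3 (0.02 log units; within the scatter), no change beyond the scatter. The 4-cyanophenyl of compound 1 sat on a sulfonyl, a different place, so an at least 4.3-fold lower number from compound 1 to compound 3 (0.63 log units; beyond the scatter) describes that attachment rather than the present change. Compound 4 keeps the benzyl attachment, so the expected step of a 1.1-fold higher number from compound 3 to compound 4 (0.04 log units; within the scatter) is small, in no direction beyond the scatter. Compound 4 is estimated at 10000 nM, within a range from 4000 nM to 28000 nM.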

Compound 4, half-maximal inhibitory concentration: > 40000 nM
Compound 4 ended at the assay's limit; the forecaster's own chance of this, stated with the estimate: 15%; at least 4.0-fold (0.60 log units) between middle value and limit.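

Once the benzyl attachment on the amine nitrogen in a ring is kept, the choice of aryl substituent can still shift the read-out: 4-cyanophenyl in place of 3,4-difluorophenyl gives an at least 4.3-fold higher number from compound 3 to compound 4 (0.63 log units; beyond the scatter), and cyano in place of 2-(methoxycarbonyl)ethenyl on an aromatic carbon gives an at least 4.5-fold higher number from compound 2 to compound 4 (0.66 log units; beyond the scatter). Compound 2 and compound 3 lie within the scatter of each other, so this position does not accept every exchange equally, as that pair alone might have suggested. Compound 1 and compound 4, the two that carry a 4-cyanophenyl, share one limit of the assay rather than a number, so the step between them cannot be read and the sulfonyl of compound 1 is no longer the only difference to weigh: the limit of > 40000 nM in this assay, at which 2 of the 4 values shown sit.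

The compounds shown do not separate the entry of the nitrile from the loss of the two fluorines, and an unsubstituted benzyl would speak to that. Nor do they show whether an amine or a carboxylic acid in place of the nitrile would stay at that limit.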